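Removing the Carboxy Group from an Ethoxy Side Chain

The source may hold more compounds than are shown below. What is called first, only, known or untested is meant among the compounds shown, and "the series" means these compounds.

Two compounds share one core. Compound 1 `CC(C)(C)c1ccc(C(=O)NCc2ccc(OC(F)(F)F)cc2)cc1` carries a trifluoromethyl on the oxygen on the aromatic ring and gives, in an assay on HeLa cells with Bile acid receptor (Homo sapiens) as the target, read by a luciferase reporter, with a stated time of 24 h (a lower number here means that less compound is needed, a higher number that more compound is needed for the effect), 160 nM. Compound 2 `CC(C)(C)c1ccc(C(=O)NCc2ccc(OCC(=O)O)cc2)cc1` carries a carboxymethyl on that oxygen instead and in this assay gives 730 nM. Of the two numbers, compound 2 has the higher one: a 4.6-fold higher number from compound 1 to compound 2 (0.66 log units; beyond the scatter).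

Compound 3 `CCOc1ccc(CNC(=O)c2ccc(C(C)(C)C)cc2)cc1` is not yet measured. It differs from compound 2 by methyl in place of carboxy on a saturated chain carbon bound to an oxygen on an aromatic ring, so the carboxymethoxy group becomes an ethoxy group. For the measured compounds named here, only one measured step bears on this, and only indirectly: a 4.6-fold higher number from compound 1 to compound 2 (0.66 log units; beyond the scatter) shows that exchanging trifluoromethyl for carboxymethyl on that oxygen raised the number beyond the scatter. Taking the carboxy away again brings compound 3 part of the way back toward compound 1, so a modest drop in the number is expected, a 2.4-fold lower number from compound 2 to compound 3 (0.39 log units; beyond the scatter), though nothing in the data says whether an ethyl behaves like a trifluoromethyl here. Compound 3 is therefore estimated at 300 nM in this assay, within a range from 100 nM to 900 nM.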

Compound 3, half-maximal effective concentration: 160 nM
Compound 3: middle estimate off by 1.9-fold (0.27 log units), on the high side; low and high end bracket the measured number.
By their numbers in this assay, from the lowest: compounds 1 and 3 (each within the scatter of the next); then compound 2.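

In this assay, replacing the carboxy with methyl gives a 4.6-fold lower number from compound 2 to compound 3 (0.66 log units; beyond the scatter) and so cancels the whole of the earlier rise, a 4.6-fold higher number from compound 1 to compound 2 (0.66 log units; beyond the scatter) in the other direction. The second new comparison gives no change at the digits printed from compound 1 to compound 3 (within the scatter) on going to an ethyl on that oxygen. Compound 1 and compound 2 alone could not separate two readings of the earlier step, the arrival of the carboxy and the loss of the trifluoromethyl; compound 3 has neither group and still sits level with compound 1, so within these three compounds the higher number goes with the carboxy, and the trifluoromethyl is not needed to keep the number at that level. Why the carboxy goes with a higher number cannot be said, as no measurement here addresses the cause.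

On these data alone, it remains open how much room this position allows, as a longer chain such as propoxy or a shorter one such as methoxy could hold the number level or shift it. An amine at the end of the chain, or a methyl ester in place of the carboxy, would show whether other groups at this spot also go with a higher number.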